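Imidazole amide to cyanophenyl amide: a toxicity expectation

A few compounds are considered here, and "the series" means these few. Any claim that something is new, unique, unknown or untested is made for them only; others in the source may bear on it.

The account follows compound 1 `COc1ccc(-c2cnc(NC(=O)c3cnc[nH]3)n2C)cc1` and the change that leads to compound 4 `COc1ccc(-c2cnc(NC(=O)c3cccc(C#N)c3)n2C)cc1`. In a toxicity assay on THP-1 cells (Homo sapiens) for inhibition (a lower number here means that less compound is tolerated, a higher number that more compound is tolerated), compound 1 gives > 100000 nM, which is a limit of the assay rather than a number. Two further compounds share the core. Compound 2 `COc1ccc(-c2cnc(NC(=O)c3ccc(F)cc3)n2-c2ccccc2)cc1` in this assay gives 8800 nM. Compound 3 `Cc1cccc(-c2cnc(NC(=O)c3ccc(F)cc3)n2C)c1` in this assay gives > 100000 nM, again a limit of the assay. Compound 1 thus stands at the limit of > 100000 nM in this assay, at which 2 of the 3 values shown sit. Compound 4 differs from compound 1 in one place: 3-cyanophenyl in place of 1H-imidazol-5-yl on a carbonyl carbon. For the measured compounds named here, no step between measured compounds is available, so the size of the change can only be judged from compound 3, which likewise carries a six-membered aromatic ring of carbon only on the carbonyl carbon and in this assay gives > 100000 nM. Compound 4 is therefore expected to give 100000 nM, most likely reported as a limit, within a range from 30000 nM to 300000 nM. This estimate means a step of a number no higher from compound 1 to compound 4 (the limit leaves the size open), expected to be none beyond the scatter.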

Compound 4, half-maximal cytotoxic concentration: > 100000 nM
Compound 4 gave a limit, no number (the forecaster's own chance of this, stated with the estimate: 70%); the middle value lies on the limit itself.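

For the compounds shown here, compound 1 and compound 4 both give only a limit, so no step between them can be read: the limit of > 100000 nM in this assay, at which 3 of the 4 values shown sit. The compounds shown leave open what actual number either compound would give, and so whether 3-cyanophenyl in place of 1H-imidazol-5-yl on a carbonyl carbon changes the result at all.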